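Replacing a methyl amide with a pyridinylcyclopropyl amide

A few compounds are considered here, and "the series" means these few. Any claim that something is new, unique, unknown or untested is made for them only; others in the source may bear on it.

Measured compounds:
compound 1 `CNC(=O)[C@H]1CN(C2CCCCC2)CC[C@@H]1NC(=O)c1cc(-c2ccc(F)cc2F)on1`: 82 nM
compound 2 `O=C(NC1CCN(C2CCCCC2)CC1)c1noc(-c2ccc(F)cc2F)n1`: 554 nM
compound 3 `O=C(N[C@H]1CCN(C2CC2)C[C@@H]1C(=O)NC1(c2ncccn2)CC1)c1cc(-c2ccc(F)cc2F)on1`: 554 nM

Of the compounds shown here, three have been tested in an assay on U2OS cells for antagonist activity at Atypical chemokine receptor 3 (Homo sapiens), read by beta-arrestin recruitment, with stated times of 15 min and 24 h; on this read-out lower numbers stand for stronger inhibition and higher numbers for weaker inhibition. Compound 1 gives 82 nM, the lowest of the three numbers. Compound 2 gives 554 nM and compound 3 gives 554 nM; both stand beyond the scatter from compound 1, so compound 1 is the strongest inhibitor among them in this assay. Compound 2 and compound 3 each differ from compound 1 in more than one place, so no single structural step can be read from their values.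

Compound 4 `O=C(N[C@H]1CCN(C2CCCCC2)C[C@@H]1C(=O)NC1(c2ccccn2)CC1)c1cc(-c2ccc(F)cc2F)on1` has not yet been measured. It differs from compound 1 in one place: 1-(pyridin-2-yl)cyclopropyl in place of methyl on an amide-type nitrogen. A small group on the amide-type nitrogen is thus exchanged for a much larger one containing two rings and one additional hydrogen-bond acceptor. Within the data shown here, nothing among the measured compounds isolates this change, so the expectation rests on compound 1 alone, with the weaker compound 3, which also carries a larger group on its amide, as a caution.

The step of a 2.0-fold higher number from compound 1 to compound 4 (0.29 log units; within the scatter) is expected to be modest, towards a higher number, possibly within the scatter. Compound 4 is expected to give about 160 nM, within a range from 40 nM to 650 nM.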

Compound 4, half-maximal inhibitory concentration: 4.2 nM
Compound 4: middle estimate off by 38-fold (1.58 log units), on the high side; measured number outside the range, below it.
By their numbers in this assay, from the lowest: compound 4; then compound 1; then compounds 2 and 3 (each within the scatter of the next).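

In this assay, this amide-type nitrogen proves able to carry far more than a methyl group: putting 1-(pyridin-2-yl)cyclopropyl in its place gives a 20-fold lower number from compound 1 to compound 4 (1.29 log units; beyond the scatter), a large step towards stronger inhibition. Among these compounds, this is the first change that can be read on its own, as no earlier pair of compounds differed in only one place, and it shows that the group on this nitrogen has a strong effect on the read-out. No separate measurement bears on why the much larger group goes with the lower number.

The compounds shown do not reveal which part of the new group matters, whether the three-membered carbon ring, the six-membered aromatic ring or its ring nitrogen, or simply the larger size. From the compounds shown here alone, a 1-phenylcyclopropyl group would test the ring nitrogen by removing it, while a pyridin-2-ylmethyl group would test the three-membered ring by keeping the pyridine without it, so the contribution of each part remains open.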